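The source may hold more compounds than are shown below. What is called first, only, known or untested is meant among the compounds shown, and "the series" means these compounds.

The study measures three compounds in an assay on HEK293 cells for binding affinity to adenosine receptor A2b (Homo sapiens), read by radioligand binding; on this read-out higher numbers stand for weaker inhibition and lower numbers for stronger inhibition. Compound 1 `C=CCn1c(=O)[nH]c2[nH]cnc2c1=O` gives 461 nM in this assay. Compound 2 `C#CCn1cnc2c1c(=O)n(C)c(=O)n2C` gives 9460 nM in this assay, and compound 3 `Cn1cnc2c1c(=O)n(CC(=O)O)c(=O)n2C` gives 23500 nM in this assay. Compound 3 thus stands at the highest of the three numbers: its nearest neighbour is compound 2, whose number lies lower by a margin beyond the scatter, and compound 1 stands furthest away with a far lower number, also beyond the scatter.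

Compound 4 `CC(=O)Cn1c(=O)c2c(ncn2C)n(C)c1=O` has not yet been measured. It differs from compound 3 in one place: methyl in place of hydroxy on a carbonyl carbon. For the measured compounds named here, no pair of measured compounds differs in just this way, so the size of the step has to be judged from what compounds 2 and 3 show. Because compound 2 lacks the carboxy group and gives 9460 nM while compound 3 gives 23500 nM, a move toward a lower number is expected for compound 4, of modest size but beyond the scatter. The step expected from compound 3 to compound 4 is therefore a 2.9-fold lower number from compound 3 to compound 4 (0.47 log units; beyond the scatter). Compound 4 is estimated at 8000 nM in this assay, within a range from 2500 nM to 25000 nM.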

Compound 4, inhibition constant: 20800 nM
The estimate for compound 4 lay 2.6-fold (0.41 log units) below the measured number; the measured number falls inside the stated range.
By their numbers in this assay, from the lowest: compound 1; then compound 2; then compounds 4 and 3 (each within the scatter of the next).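

In this assay, for the compounds shown here, the exchange of carboxy for acetyl gives a 1.1-fold lower number from compound 3 to compound 4 (0.05 log units; within the scatter), the first step in this set that can be read at a single place, and it puts the two numbers within the scatter of each other. At this carbonyl carbon, on a saturated chain carbon, methyl can therefore stand in place of hydroxy, and the hydrogen-bond donor counted on the hydroxy can go, without a difference that this read-out separates from repeat scatter, though this holds only for this one pair. No measured information bears on why these two compounds read alike.

The compounds shown leave open how the number responds when the carbonyl itself gives way, as with a plain propyl chain or an amine in place of 2-oxopropyl, or when a longer chain carries the carboxy group. They also leave open whether carboxymethyl and 2-oxopropyl would read alike on the core of compound 1, which gives 461 nM.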